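Removing one fluoro from compound 3

The compounds below may be only part of what the source reports. "The series", "measured", "known", "first", "only" and "open" are said of these compounds alone.

Measured so far:
compound 1 `c1ccc(Oc2ncnc3[nH]ccc23)cc1` — 3200 nM
compound 2 `Fc1cccc(Oc2ncnc3[nH]ccc23)c1F` — 2700 nM
compound 3 `Fc1ccc(Oc2ncnc3[nH]ccc23)cc1F` — 3000 nM

In an assay on HEK293-TREx cells for antagonist activity at transient receptor potential cation channel subfamily A member 1 (Homo sapiens), read by fluorescence and calcium flux, with a stated time of 72 h (on this read-out lower numbers stand for stronger inhibition and higher numbers for weaker inhibition), compound 1 gives 3200 nM, compound 2 gives 2700 nM and compound 3 gives 3000 nM. Compound 3 holds the second highest of the three numbers; its gaps to compound 1 and to compound 2 both lie within the scatter, so these three compounds cannot be ordered on the data in hand. Compound 4 `Fc1cccc(Oc2ncnc3[nH]ccc23)c1` is the next step: hydrogen in place of fluoro on an aromatic carbon, on an aromatic carbon of a six-membered aromatic ring of carbon only, ortho to a fluoro group and para to a large group. Going by the values given here, no measured pair isolates this change. The fluoro patterns tried so far all give numbers within the scatter of one another, and no step beyond the scatter is expected in this assay in either direction. Compound 4 is expected near 3000 nM, with a range from 1500 nM to 6000 nM. The expected step is no change at the digits printed from compound 3 to compound 4 (within the scatter).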

Compound 4, half-maximal inhibitory concentration: > 32000 nM
Compound 4 was reported as a limit; the forecaster's own chance of this, stated with the estimate: 5%; at least 10-fold (1.02 log units) between middle value and limit.
By their numbers in this assay, from the lowest: compounds 2, 3 and 1 (each within the scatter of the next). At a limit, above all of these: compound 4.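

In this assay the result for compound 4 is a limit, not a number: the limit of > 32000 nM in this assay, at which 1 of the 4 values shown sits.
Hydrogen in place of fluoro on this carbon, para to a large group, gives an at least 10-fold higher number from compound 3 to compound 4 (1.02 log units; beyond the scatter), and the same replacement gives an at least 11-fold higher number from compound 2 to compound 4 (1.07 log units; beyond the scatter). A single fluoro is thus not equivalent to the patterns in compound 2 and compound 3, and fluoro in place of hydrogen gives an at least 10-fold higher number from compound 1 to compound 4 (1.00 log units; beyond the scatter), although compound 1 carries no fluoro at all.

Open, on these data alone, is whether the other single-fluoro placements behave like compound 4. Also open, as far as these compounds go, is how a chloro, a methoxy group or an amine on this carbon would read.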